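Same Chain Change, Now on the Cyano-Bearing Core

This account rests on a few compounds, and the source may have more. Where it says the series, first, only, none or still open, it means among the compounds named here.

Of the compounds shown here, three have been measured in a functional assay on HeLa cells (Homo sapiens) for inhibition, read by MTT assay, with a stated time of 72 h; on this read-out lower numbers stand for stronger inhibition and higher numbers for weaker inhibition. Compound 1 `COc1cccc(Nc2nc(Oc3cccc(NC(=O)/C=C/C(C)C)c3)c3sccc3n2)c1` gives 27000 nM in this assay. Compound 2 `CCC/C=C/C(=O)Nc1cccc(Oc2nc(Nc3cccc(OC)c3)nc3ccsc23)c1` differs from compound 1 by propyl in place of isopropyl on a double-bonded chain carbon bound to a double-bonded chain carbon; compound 2 gives 7730 nM, and this change made a 3.5-fold lower number from compound 1 to compound 2 (0.54 log units; beyond the scatter). Compound 3 `CC(C)/C=C/C(=O)Nc1cccc(Oc2nc(Nc3cccc(C#N)c3)nc3ccsc23)c1` differs from compound 1 by cyano in place of methoxy on an aromatic carbon; compound 3 gives 36500 nM, and here the change made only a 1.4-fold higher number from compound 1 to compound 3 (0.13 log units; within the scatter).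

Compound 4 `CCC/C=C/C(=O)Nc1cccc(Oc2nc(Nc3cccc(C#N)c3)nc3ccsc23)c1` has not yet been measured. It differs from compound 3 by propyl in place of isopropyl on a double-bonded chain carbon bound to a double-bonded chain carbon, and the place of the change is described in the same words as for the change from compound 1 to compound 2, so it is the same change made on a different core. The two cores differ by cyano in place of methoxy on an aromatic carbon.

The expectation for compound 4 rests on one earlier case, the change from compound 1 to compound 2 with its step of a 3.5-fold lower number from compound 1 to compound 2 (0.54 log units; beyond the scatter). Carrying a step of the same size over to compound 3 with its value of 36500 nM, the step from compound 3 to compound 4 is expected to be a 3.5-fold lower number from compound 3 to compound 4 (0.55 log units; beyond the scatter). Compound 4 is therefore estimated at 10400 nM in this assay, with a likely range from 4500 nM to 25000 nM.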

Compound 4, half-maximal inhibitory concentration: 42100 nM
Compound 4: the middle estimate sits 4.0-fold (0.61 log units) below what was measured; the measured number lies above the stated range.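

In this assay, the change from isopropyl to propyl did not carry over from one core to the other, for on the core of compound 3 it gave a 1.2-fold higher number from compound 3 to compound 4 (0.06 log units; within the scatter), and this step differs from the earlier one: the same change on two cores in this assay, a 3.5-fold lower number (0.54 log units; beyond the scatter) from compound 1 to compound 2 and a 1.2-fold higher number (0.06 log units; within the scatter) from compound 3 to compound 4, 4.0-fold (0.61 log units) apart, beyond the scatter of two such steps. Read the other way, cyano in place of methoxy gave a 5.4-fold higher number from compound 2 to compound 4 (0.74 log units; beyond the scatter) with the propyl chain, and this step too differs from its counterpart with the isopropyl chain: the same change on two cores in this assay, a 1.4-fold higher number (0.13 log units; within the scatter) from compound 1 to compound 3 and a 5.4-fold higher number (0.74 log units; beyond the scatter) from compound 2 to compound 4, 4.0-fold (0.61 log units) apart, beyond the scatter of two such steps. So within these compounds the effect of the chain change depends on which group the core carries, but two pairs on two cores cannot show why this happens or how general it is.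

From the compounds shown here alone, it remains open whether a longer chain in place of propyl would keep the lower number on the core of compound 1 and stay flat on the core of compound 3. Also open, going by these compounds, is how the chain change would behave with an amine or a carboxylic acid in place of cyano.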